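The source may hold more compounds than are shown below. What is called first, only, known or untested is meant among the compounds shown, and "the series" means these compounds.

Values measured in an ADME assay on L6 cells (Rattus norvegicus) for cytotoxicity, read by resazurin assay, with a stated time of 70 h; a lower number here means a stronger inhibitor, a higher number a weaker inhibitor:
- compound 1 `COc1cc(NC(C)CCCNC(=O)Nc2cccc(O)c2)c2ncccc2c1`: 38 ug/mL
- compound 2 `COc1cc(NC(C)CCCNC(=O)Nc2cccc(C(F)(F)F)c2)c2ncccc2c1`: 150 ug/mL
- compound 3 `COc1cc(NC(C)CCCNC(=O)NNC(=O)Nc2cccc(Cl)c2)c2ncccc2c1`: 27.6 ug/mL

Compound 3 gives 27.6 ug/mL, at the low end of these numbers. The data show a 1.4-fold lower number from compound 1 to compound 3 (0.14 log units; within the scatter), so the clear separation is a 5.4-fold lower number from compound 2 to compound 3 (0.74 log units; beyond the scatter).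

The next compound is compound 4 `COc1cc(NC(C)CCCNC(=O)NNC(=O)Nc2ccc(C(F)(F)F)cc2)c2ncccc2c1`, which differs by 4-(trifluoromethyl)phenyl in place of 3-chlorophenyl on an amide-type nitrogen. Among the measured compounds shown here, no measured pair makes this exchange directly. The closest evidence is a 3.9-fold higher number from compound 1 to compound 2 (0.60 log units; beyond the scatter), with trifluoromethyl in place of hydroxy on an aromatic carbon, but there hydroxy leaves rather than chlorine. The other two steps change the group on the amide-type nitrogen as a whole, so they cannot isolate the aryl substituent. A modest rise is therefore possible, but the evidence for it is indirect. The expected step is a 1.1-fold higher number from compound 3 to compound 4 (0.04 log units; within the scatter), which would not be a clear change. In this assay the estimate for compound 4 is 30 ug/mL, with an expected range of 12 ug/mL to 75 ug/mL.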

Compound 4, half-maximal inhibitory concentration: 7.5 ug/mL
The estimate for compound 4 lay 4.0-fold (0.60 log units) above the measured number, outside the stated range (below it).
By their numbers in this assay, from the lowest: compound 4; then compounds 3 and 1 (each within the scatter of the next); then compound 2.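

The aryl group on the amide-type nitrogen proves to be a position that matters in this assay: with the rest of the molecule unchanged, 4-(trifluoromethyl)phenyl in place of 3-chlorophenyl gives a 3.7-fold lower number from compound 3 to compound 4 (0.57 log units; beyond the scatter). Earlier steps had replaced this group only as a whole or had changed a substituent on a different chain, and the one earlier entry of trifluoromethyl went the other way, with a 3.9-fold higher number from compound 1 to compound 2 (0.60 log units; beyond the scatter), so its arrival does not move the number in one fixed direction across these compounds. Nothing available explains why the number falls at this position.

Since the chlorine leaves and the trifluoromethyl enters on differently numbered ring positions in one step, the compounds shown cannot separate the identity of the substituent from its place on the ring. As far as these compounds go, it remains open how 4-chlorophenyl, or a phenyl ring carrying a carboxylic acid or an amine, would read on this same chain.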